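The source may report more compounds than this note shows. Statements on the series, on what has been measured and on what is new or still open speak of the compounds shown alone.

Measured in a functional assay on MDA-MB-231 cells (Homo sapiens) for inhibition, read by sulforhodamine B assay, with a stated time of 48 h; on this read-out lower numbers stand for stronger inhibition of growth and higher numbers for weaker inhibition of growth:
Compound 1 `COc1ccc(-c2cc(/C=C/C(=O)c3ccc(N)cc3)[nH]n2)cc1` gives 8290 nM.
Compound 3 `COc1ccc(C(=O)/C=C/c2cc(-c3cc(OC)c(OC)c(OC)c3)n[nH]2)cc1OC` gives 3060 nM.
For compound 2 `COc1cc(-c2cc(/C=C/C(=O)c3ccc(Cl)c(Cl)c3)[nH]n2)cc(OC)c1OC` this assay reports only a limit, > 100000 nM (the limit of > 100000 nM in this assay, at which 1 of the 3 values shown sits).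

Of the two numbers, compound 1 stands higher, and the number for compound 3 lies below it by a margin beyond the scatter. For the measured compounds named here, the single measured step, an at least 32-fold lower number from compound 2 to compound 3 (1.51 log units; beyond the scatter), concerns the aryl on the carbonyl carbon. Compound 4 `COc1ccc(-c2cc(/C=C/C(=O)c3ccc(N)cc3)[nH]n2)cc1OC` differs from compound 1 at another place: methoxy in place of hydrogen on an aromatic carbon, on the aryl joined to the shared core. Going by the values given here, no measured step alters that ring, so the step from compound 2 to compound 3 speaks to the change only loosely, as a change of substituents on a phenyl ring elsewhere in the molecule. Compound 3, which carries three methoxy groups on the ring joined to the core, gives the lower of the two numbers, but its aryl on the carbonyl carbon also differs from that of compound 1, so the two changes cannot be separated. The account therefore expects for compound 4 a small step, a 1.4-fold lower number from compound 1 to compound 4 (0.14 log units; within the scatter), toward a lower number but within the scatter. Compound 4 is estimated at 6000 nM, with a range from 2000 nM to 20000 nM.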

Compound 4, concentration for total growth inhibition: 17200 nM
Beside the measured number, compound 4's estimate is 2.9-fold (0.46 log units) below it, within the range that was stated.
By their numbers in this assay, from the lowest: compound 3; then compound 1; then compound 4. At a limit, above all of these: compound 2.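

For the compounds shown here, with methoxy in place of hydrogen on an aromatic carbon of the aryl joined to the shared core, ortho to a methoxy group and meta to a large group, this assay gives the first measured step at this ring: a 2.1-fold higher number from compound 1 to compound 4 (0.32 log units; beyond the scatter) is a modest move toward weaker inhibition of growth. On the 4-aminophenyl ketone of compound 1, then, this added methoxy does not lower the number. Nothing measured here accounts for the direction of this step.

The compounds shown leave open how a hydroxyl, a fluorine or an amine at the same place would compare with methoxy. They also leave open whether the same methoxy change would run the same way with another aryl on the carbonyl carbon, such as 3,4-dimethoxyphenyl.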